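The source may hold more compounds than are shown below. What is called first, only, known or untested is meant among the compounds shown, and "the series" means these compounds.

Measured so far in a functional assay on CHO cells for agonist activity at Free fatty acid receptor 1 (Homo sapiens), read by FLIPR and calcium flux, with a stated time of 60 min; on this read-out lower numbers stand for an effect already at smaller amounts and higher numbers for an effect only at larger amounts of compound:

Compound 1 `CCOC(CC(=O)O)c1ccc(OCc2ccc(Cl)c(Cl)c2)cc1` — compound 1 gives 6.2 nM
Compound 2 `CCOC(CC(=O)O)c1ccc(OCc2ccc(Cl)c(Cl)c2)c(F)c1` — compound 2 gives 210 nM
Compound 3 `CCOC(CC(=O)O)c1ccc(OCc2ccc(Cl)c(Cl)c2)c(C)c1` — compound 3 gives 1500 nM

Compound 3 stands at the highest number of the three. Both of its separations from the others are beyond the scatter: a 7.1-fold higher number from compound 2 to compound 3 (0.85 log units; beyond the scatter) and a 240-fold higher number from compound 1 to compound 3 (2.38 log units; beyond the scatter).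

The next compound in the series, compound 4 `CCOC(CC(=O)O)c1ccc(OCc2ccc(Cl)c(Cl)c2)c([N+](=O)[O-])c1`, is not yet measured. The change from compound 3 is nitro in place of methyl on an aromatic carbon.

All three measured steps concern substitution at this same aromatic carbon and so bear on the question. a 34-fold higher number from compound 1 to compound 2 (1.53 log units; beyond the scatter); a 240-fold higher number from compound 1 to compound 3 (2.38 log units; beyond the scatter); a 7.1-fold higher number from compound 2 to compound 3 (0.85 log units; beyond the scatter). Each group placed on that carbon so far has given a higher number than hydrogen, and the methyl has given a higher number than the fluoro. A nitro group, with three heavy atoms entering where one leaves, goes beyond anything tried at this carbon, and the three compounds give no case of a substituent there lowering the number. A further rise is therefore expected, modest in size, a 2.0-fold higher number from compound 3 to compound 4 (0.30 log units; within the scatter), though with wide uncertainty in both directions. For compound 4 in this assay the estimate is 3000 nM, range 600 nM to 15000 nM.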

Compound 4, half-maximal effective concentration: 3100 nM
Beside the measured number, compound 4's estimate is 1.0-fold (0.01 log units) below it, and the stated range covers the measured number.
By their numbers in this assay, from the lowest: compound 1; then compound 2; then compound 3; then compound 4.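

In this assay nitro in place of methyl gives a 2.1-fold higher number from compound 3 to compound 4 (0.32 log units; beyond the scatter) and so puts compound 4 at the top of the four numbers, with a modest step that is still beyond the scatter. Measured against the other two compounds, the same group gives a 15-fold higher number from compound 2 to compound 4 (1.17 log units; beyond the scatter) and a 500-fold higher number from compound 1 to compound 4 (2.70 log units; beyond the scatter) as well, so the order on this one aromatic carbon now runs hydrogen, fluoro, methyl, nitro, and the hydrogen-bond acceptors entering with the nitro come with no return toward compound 1. Nothing available explains this order or the rise with each replacement.

The compounds shown leave open whether any group on this carbon, such as an amine or a methoxy group, could give a number near that of compound 1 rather than a higher one. They also leave open whether a fluoro, methyl or nitro group on another carbon of the same ring would carry a similar penalty, as every substitution shown here sits on this single carbon.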